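Swapping the small ring of compound 2

A few compounds are considered here, and "the series" means these few. Any claim that something is new, unique, unknown or untested is made for them only; others in the source may bear on it.

- Compound 1 `CC/C=C\[C@H](C)[C@H](OC(N)=O)[C@@H](C)[C@H](O)[C@@H](C)C/C(C)=C\[C@H](C)[C@@H](O)[C@@H](C)/C=C\[C@@H](O)C[C@@H]1OC(=O)[C@H](C)C[C@H]1C` gives 65 nM
- Compound 2 `CC/C=C\[C@H](C)[C@H](OC(N)=O)[C@@H](C)[C@H](O)[C@@H](C)C/C(C)=C\[C@H](C)[C@@H](O)[C@@H](C)/C=C\[C@@H](O)C[C@H]1CCC(=O)O1` gives 285 nM

In a functional assay on CCRF-CEM cells (Homo sapiens) for antiproliferative activity (on this read-out higher numbers stand for weaker inhibition of growth and lower numbers for stronger inhibition of growth), compound 2 has the higher of the two numbers, so it is the weaker growth inhibitor of this pair. Compound 3 `CC/C=C\[C@H](C)[C@H](OC(N)=O)[C@@H](C)[C@H](O)[C@@H](C)C/C(C)=C\[C@H](C)[C@@H](O)[C@@H](C)/C=C\[C@@H](O)C[C@@H]1OC(=O)[C@H](C)[C@@H](OC)[C@H]1C` differs from compound 2 in one place: a group of 11 heavy atoms (8 carbon, 3 oxygen; one six-membered non-aromatic ring with 1 hetero atom) in place of a group of 6 heavy atoms (4 carbon, 2 oxygen; one five-membered non-aromatic ring with 1 hetero atom), on a saturated chain carbon, two bonds along the chain from a double-bonded chain carbon and an oxygen on a saturated carbon. For the measured compounds named here, the only measured step that bears on this change is a 4.4-fold higher number from compound 1 to compound 2 (0.64 log units; beyond the scatter), a modest difference beyond the scatter. That step links a six-membered ring with 1 hetero atom in compound 1 to a five-membered ring with 1 hetero atom in compound 2. Compound 3 also carries a six-membered ring, so a step of similar size is expected, but towards a lower number. Going by the values given here, its group is larger than the one in compound 1, however, and no measurement shows what those extra atoms do, so the uncertainty is wide. The expected change is a 3.2-fold lower number from compound 2 to compound 3 (0.50 log units; beyond the scatter). For compound 3 the estimated value is 90 nM, with an expected range from 30 nM to 270 nM.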

Compound 3, concentration for 50% growth inhibition: 79 nM
The estimate for compound 3 lay 1.1-fold (0.06 log units) above the measured number; low and high end bracket the measured number.
By their numbers in this assay, from the lowest: compounds 1 and 3 (each within the scatter of the next); then compound 2.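

In this assay, the group with the six-membered ring in compound 3 again gives a lower number than the five-membered ring group, with a 3.6-fold lower number from compound 2 to compound 3 (0.56 log units; beyond the scatter), so a second six-membered ring compound now stands apart from compound 2 in the same direction as compound 1. The new information is that methoxy in place of hydrogen on a saturated ring carbon leaves the read-out practically unmoved, with a 1.2-fold higher number from compound 1 to compound 3 (0.08 log units; within the scatter), so this ring carbon can carry methoxy with no shift that can be told from ordinary assay noise. Nothing available explains why the six-membered ring compounds differ from compound 2 or why the methoxy makes no clear difference.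

The group in compound 2 differs from those in compound 1 and compound 3 in more than ring size, since it also has fewer carbons and fewer stereocentres, so these compounds cannot show whether ring size alone matters. They also leave open whether the same saturated ring carbon would accept something other than methoxy, such as a hydroxyl, an amine or a longer chain like butoxy.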